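Cyano in Place of Bromo on the Benzamide of Compound 1

The compounds below may be only part of what the source reports. "The series", "measured", "known", "first", "only" and "open" are said of these compounds alone.

Compound 1 `COc1cc2oc(-c3cccc(NC(=O)c4ccc(Br)cc4)c3)cc(=O)c2c(OC)c1OC` and compound 2 `COc1cc2oc(-c3cccc(NC(=O)c4ccccc4Br)c3)cc(=O)c2c(OC)c1OC` share one core and differ only in the bromophenyl on the carbonyl carbon. Going by the values given here, in a functional assay on MCF7 cells (Homo sapiens) for inhibition, read by MTT assay (on this read-out lower numbers stand for stronger inhibition of growth and higher numbers for weaker inhibition of growth), compound 1 gives 9650 nM, the lowest of the two numbers measured so far, while compound 2 gives 55000 nM. Among the compounds with values here, the one measured step, a 5.7-fold higher number from compound 1 to compound 2 (0.76 log units; beyond the scatter), is a modest move toward weaker growth inhibition.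

Compound 3 `COc1cc2oc(-c3cccc(NC(=O)c4ccc(C#N)cc4)c3)cc(=O)c2c(OC)c1OC` has not yet been measured. Against compound 1 its change is cyano in place of bromo on an aromatic carbon. Within the data shown here, no measured step exchanges bromo for cyano; the only step available, a 5.7-fold higher number from compound 1 to compound 2 (0.76 log units; beyond the scatter), shifts the bromo rather than replacing it, and so it bears on the present change only loosely, showing that alterations to this part of compound 1 have so far given modest movement. With nothing pointing to a large move in either direction, the step from compound 1 to compound 3 is expected to stay within the scatter, a 1.2-fold higher number from compound 1 to compound 3 (0.09 log units; within the scatter). The estimate for compound 3 in this assay is 12000 nM, expected to lie between 4000 nM and 40000 nM.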

Compound 3, concentration for 50% growth inhibition: 12700 nM
Beside the measured number, compound 3's estimate is 1.1-fold (0.02 log units) below it; low and high end bracket the measured number.
By their numbers in this assay, from the lowest: compounds 1 and 3 (each within the scatter of the next); then compound 2.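

In this assay, a 1.3-fold higher number from compound 1 to compound 3 (0.12 log units; within the scatter) shows that this carbon, para to a large group, accepts cyano in place of bromo with no change that can be told from the scatter, even though the group entering has a hydrogen-bond acceptor and the one leaving has none. Going by these compounds alone, this is the first exchange of the group itself rather than a shift of it, and it places the 4-cyanophenyl of compound 3 level with the 4-bromophenyl of compound 1. In turn, a 4.3-fold lower number from compound 2 to compound 3 (0.64 log units; beyond the scatter) leaves compound 2, with its 2-bromophenyl, apart from both, although that step changes the group and its place together; no measured finding here explains why these numbers fall as they do.

The compounds shown leave open whether an amine, a carboxylic acid or a methoxy group on this same carbon would also stay level with bromo and cyano. Within the data shown here, they also leave open whether a 2-cyanophenyl would fall with compound 2, since only one group has so far been seen in that other place.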